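An Ester in Place of Isopropyl: Little Change Expected

The compounds below may be only part of what the source reports. "The series", "measured", "known", "first", "only" and "open" are said of these compounds alone.

Three measured compounds share one core and differ only in the side chain of an amino-acid ester joined through an amide. Compound 1 `COC(=O)[C@H](NC(=O)Cn1cc(C2=C(c3c[nH]c4ccccc34)C(=O)N(C)C2=O)c2ccccc21)[C@@H](C)O` carries a 1-hydroxyethyl group there. In a functional assay on Bel-7402 cells (Homo sapiens) for cytotoxicity, read by MTT assay, with a stated time of 24 h (on this read-out lower numbers stand for stronger inhibition and higher numbers for weaker inhibition), compound 1 reaches only the assay limit of > 100000 nM. Compound 2 `COC(=O)CC[C@@H](NC(=O)Cn1cc(C2=C(c3c[nH]c4ccccc34)C(=O)N(C)C2=O)c2ccccc21)C(=O)OC` gives 47400 nM in this assay, and compound 3 `COC(=O)[C@@H](CC(C)C)NC(=O)Cn1cc(C2=C(c3c[nH]c4ccccc34)C(=O)N(C)C2=O)c2ccccc21` gives 42400 nM. The two steps away from compound 1 are an at least 2.1-fold lower number from compound 1 to compound 2 (0.32 log units; beyond the scatter) and an at least 2.3-fold lower number from compound 1 to compound 3 (0.37 log units; beyond the scatter), both beyond the usual scatter. Between the two measured numbers the step is a 1.1-fold lower number from compound 2 to compound 3 (0.05 log units; within the scatter), so compound 3 holds the lowest of the two numbers while sitting within the scatter of compound 2.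

Compound 4 `COC(=O)C[C@@H](NC(=O)Cn1cc(C2=C(c3c[nH]c4ccccc34)C(=O)N(C)C2=O)c2ccccc21)C(=O)OC` arises from compound 3 by methoxycarbonyl in place of isopropyl on a saturated chain carbon, two bonds along the chain from an amide-type nitrogen and a carbonyl carbon. Among the compounds with values here, the only measured step at that same place is a 1.1-fold lower number from compound 2 to compound 3 (0.05 log units; within the scatter), which exchanged an ester-bearing group for isopropyl and stayed within the scatter. Putting a smaller ester group back in place of the isopropyl is therefore expected to give a step of a 1.1-fold higher number from compound 3 to compound 4 (0.03 log units; within the scatter) in this assay, not beyond the scatter. Compound 4 is estimated at 45000 nM in this assay, with a likely range from 20000 nM to 100000 nM.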

Compound 4, half-maximal inhibitory concentration: 9360 nM
Beside the measured number, compound 4's estimate is 4.8-fold (0.68 log units) above it; the whole stated range lies above it.
By their numbers in this assay, from the lowest: compound 4; then compounds 3 and 2 (each within the scatter of the next). At a limit, above all of these: compound 1.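

In this assay, this position turns out to be sensitive to the group it carries: methoxycarbonyl in place of isopropyl gives a 4.5-fold lower number from compound 3 to compound 4 (0.66 log units; beyond the scatter), whereas the earlier exchange at this place gave only a 1.1-fold lower number from compound 2 to compound 3 (0.05 log units; within the scatter). Having an ester in the side chain is not enough on its own, for compound 2 carries one too, and shortening 2-(methoxycarbonyl)ethyl to (methoxycarbonyl)methyl still gives a 5.1-fold lower number from compound 2 to compound 4 (0.70 log units; beyond the scatter). The largest step, an at least 10-fold lower number from compound 1 to compound 4 (1.02 log units; beyond the scatter), is only a lower bound on the true difference, as compound 1 stands at a limit of the assay: the limit of > 100000 nM in this assay, at which 1 of the 4 values shown sits.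

Still open, going by these compounds, is whether a carboxylic acid or a primary amide in place of the methoxycarbonyl of compound 4 would keep its number in this assay, and whether a plain methyl or an ethyl ester would do the same. The compounds shown also give no reason for the drop, so they show only that this short ester side chain goes with the lowest number of the four, not why it does.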